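Replacing thiophen-2-yl with 3,4-dimethoxyphenyl in compound 2

The source may report more compounds than this note shows. Statements on the series, on what has been measured and on what is new or still open speak of the compounds shown alone.

Three related compounds have numbers in a functional assay on COLO 205 cells (Homo sapiens) for inhibition, read by sulforhodamine B assay, with a stated time of 48 h, tested at 50 uM; a lower number here means less inhibition of growth, a higher number more inhibition of growth at the concentration tested. Compound 2 `COc1cc(/C=C/C(=O)/C=C/c2cccs2)ccc1OCc1cn(CCOc2cc(=O)oc3ccccc23)nn1` gives 66%, the highest of the three. Compound 3 `COc1cccc(/C=C/C(=O)/C=C/c2ccc(OCc3cn(CCCOc4cc(=O)oc5ccccc45)nn3)c(OC)c2)c1` gives 52% and compound 1 `COc1ccc(/C=C/C(=O)/C=C/c2ccc(OCc3cn(CCCCCOc4cc(=O)oc5ccccc45)nn3)c(OC)c2)cc1OC` gives 43%, both lower than compound 2 by more than the usual scatter of repeated measurements.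

Compound 4 `COc1ccc(/C=C/C(=O)/C=C/c2ccc(OCc3cn(CCOc4cc(=O)oc5ccccc45)nn3)c(OC)c2)cc1OC` has not yet been measured. Its difference from compound 2 is 3,4-dimethoxyphenyl in place of thiophen-2-yl on a double-bonded chain carbon bound to a double-bonded chain carbon, and the swap sits on a double-bonded chain carbon bound to a double-bonded chain carbon. Going by the values given here, no measured pair isolates this change, so any expectation is rough. The best available clue is compound 1, which also carries 3,4-dimethoxyphenyl and gives 43%, although it differs from compound 4 elsewhere in its structure too. On that basis, a fall in this assay is expected, with an estimated a number 13 percentage points lower from compound 2 to compound 4 (beyond the scatter). The estimated value for compound 4 is 53%, with an expected range of 38% to 68%.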

Compound 4, percent growth inhibition at one concentration: 80%
For compound 4 the middle estimate is 27 percentage points below the measured one; measured number outside the range, above it.
By their numbers in this assay, from the lowest: compounds 1 and 3 (each within the scatter of the next); then compound 2; then compound 4.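

In this assay, going by these compounds alone, this is the first pair that differs in one place, and 3,4-dimethoxyphenyl in place of thiophen-2-yl gives a number 14 percentage points higher from compound 2 to compound 4 (beyond the scatter) on this double-bonded chain carbon. So the thiophen-2-yl group is not needed here for growth inhibition, and this position accepts the larger aromatic ring. That group does not settle the number alone, though: compound 1 carries the same 3,4-dimethoxyphenyl on a longer chain and gives 43% in this assay, and nothing shown explains the rise.

As far as these compounds go, whether plain phenyl, or a ring bearing an amine or a carboxylic acid, would do as well here remains open. So does whether the same swap gives a similar step when the chain is longer.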